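A smaller amine on the sulfonyl sulfur: what to expect

This account rests on a few compounds, and the source may have more. Where it says the series, first, only, none or still open, it means among the compounds named here.

Compound 2 `CC(C)CN(CC(C)C)S(=O)(=O)c1ccc(NC(=O)C(C)(O)C(F)(F)F)cc1` is the point of departure. In an assay on a protein complex (Cavia porcellus) with sulfonylurea receptors; K-ATP channels (Homo sapiens) as the target (a higher number here means a weaker inhibitor, a lower number a stronger inhibitor), compound 2 is known only as a limit, > 30000 nM. Its closest measured neighbour, compound 1 `CCC(C)N(C(C)CC)S(=O)(=O)c1ccc(NC(=O)C(C)(O)C(F)(F)F)cc1`, is no better defined; in this assay compound 1 also gives a limit, > 30000 nM. The third measured compound, compound 3 `CC(O)(C(=O)Nc1ccc(/C(=N\O)c2ccccc2)cc1)C(F)(F)F`, carries the same amide but a different group on the shared core, and it too stops at a limit: in this assay compound 3 gives > 30000 nM. For the measured compounds named here, because of the limit of > 30000 nM in this assay, at which 3 of the 3 values shown sit, the only step between neighbours that differ in one place has no readable size: a step that the two limits leave unreadable from compound 1 to compound 2.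

Compound 4 `CCN(CC)S(=O)(=O)c1ccc(NC(=O)C(C)(O)C(F)(F)F)cc1` differs from compound 2 in a single spot: diethylamino in place of diisobutylamino on a sulfonyl sulfur. Going by the values given here, the one measured step at this position, the one from compound 1 to compound 2, is the unreadable one just described, so it sets neither a direction nor a size. With every measured value sitting at the limit, the step of a number no higher from compound 2 to compound 4 (the limit leaves the size open) from compound 2 to compound 4 is expected to be essentially none beyond the scatter. For compound 4 in this assay the estimated value is 30000 nM, within a range from 10000 nM to 100000 nM, and the most probable report is once again a limit rather than a number.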

Compound 4, half-maximal inhibitory concentration: 810 nM
Compound 4: middle estimate off by 37-fold (1.57 log units), on the high side; measured number below the stated range.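

The change on the sulfonyl sulfur proves to be far from silent in this assay: diethylamino brings an at least 37-fold lower number from compound 2 to compound 4 (1.56 log units; beyond the scatter), and against the other larger amine it brings an at least 37-fold lower number from compound 1 to compound 4 (1.56 log units; beyond the scatter). Among these three compounds, which differ only in the amine on the sulfonyl sulfur, diisobutylamino and bis(sec-butyl)amino give no readable number, while diethylamino, with fewer heavy atoms, gives the first one in the series, so this position can now be read. Both steps remain lower bounds on the true change, because each starts from a limit and not from a number: the limit of > 30000 nM in this assay, at which 3 of the 4 values shown sit.

The compounds shown do not tell whether a still smaller amine such as dimethylamino, or a cyclic amine such as pyrrolidine or morpholine, would carry the number lower or give back what diethylamino gained. They also leave chain length and branching tied together, as both larger amines are branched and diethylamino is not, and an unbranched dipropylamino or dibutylamino group would be needed to pull the two apart.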